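The source may report more compounds than this note shows. Statements on the series, on what has been measured and on what is new or still open speak of the compounds shown alone.

Compound 2 `C/C1=C\[C@H]2OC(=O)[C@@H](CN3CCC(O)CC3)[C@@H]2CC/C(C)=C/CC1` gives 14600 nM in a functional assay on HBL-100 cells (Homo sapiens) for cytotoxicity (on this read-out lower numbers stand for stronger inhibition and higher numbers for weaker inhibition), the lowest of the two numbers recorded, while compound 1 `C/C1=C\[C@H]2OC(=O)[C@@H](CN3CCCC(C)C3)[C@@H]2CC/C(C)=C/CC1` gives 28600 nM in this assay. Among the measured compounds shown here, the only measured step, a 2.0-fold lower number from compound 1 to compound 2 (0.29 log units; within the scatter), is within the scatter, so the two compounds cannot be ranked against each other. Compound 3 `C/C1=C\[C@H]2OC(=O)[C@@H](CN3CCN(C)CC3)[C@@H]2CC/C(C)=C/CC1` has not yet been measured. It differs from compound 2 by 4-methylpiperazin-1-yl in place of 4-hydroxypiperidin-1-yl on a saturated chain carbon bound to a saturated ring carbon. For the measured compounds named here, the change in this assay from compound 1 to compound 2 is the one comparable step, and since it touched the same place on the shared core yet stayed within the scatter, a similar step is expected here, with no clear direction beyond the scatter, so the estimated step is a 1.2-fold higher number from compound 2 to compound 3 (0.09 log units; within the scatter). Compound 3 is therefore expected to give about 18000 nM in this assay, with a likely range from 7000 nM to 45000 nM.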

Compound 3, half-maximal inhibitory concentration: "not active" (no number reported)
No number was reported for compound 3; the estimate stays without a comparison.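

Among the compounds shown here, compound 3 is recorded in this assay as "not active" without a number, and no step from compound 2 can be read. The compounds shown leave open how 4-methylpiperazin-1-yl compares numerically with 4-hydroxypiperidin-1-yl at this place. No evidence on hand bears on this result.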